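Ring swaps on the amide nitrogen of the shared core

A few compounds are considered here, and "the series" means these few. Any claim that something is new, unique, unknown or untested is made for them only; others in the source may bear on it.

Measured so far, in a functional assay on MIA PaCa-2 cells (Homo sapiens) for inhibition, read by MTT assay, with a stated time of 3 days; on this read-out higher numbers stand for weaker inhibition and lower numbers for stronger inhibition:
compound 1 `CCN(CC)S(=O)(=O)c1ccc(S(=O)(=O)N2CCC[C@@H](C(=O)N[C@H]3CC[C@H](OC)CC3)C2)cc1` gives 2290 nM
compound 2 `CCN(CC)S(=O)(=O)c1ccc(S(=O)(=O)N2CCC[C@@H](C(=O)N3CCOCC3)C2)cc1` gives 160 nM
compound 3 `CCN(CC)S(=O)(=O)c1ccc(S(=O)(=O)N2CCC[C@@H](C(=O)NC3CCOCC3)C2)cc1` gives 1350 nM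

Compound 1 stands highest of the three numbers in this assay. Its nearest neighbour is compound 3, a 1.7-fold lower number from compound 1 to compound 3 (0.23 log units; within the scatter), a step that lies within the scatter. Its furthest is compound 2, a 14-fold lower number from compound 1 to compound 2 (1.16 log units; beyond the scatter), a large step.

Compound 4 `CCN(CC)S(=O)(=O)c1ccc(S(=O)(=O)N2CCC[C@@H](C(=O)N[C@@H]3CCOC3)C2)cc1` has not yet been measured. It differs from compound 1 at one place: oxolan-3-yl in place of 4-methoxycyclohexyl on an amide-type nitrogen. The amide hydrogen is kept, as in compound 3.

Among the compounds with values here, of the measured steps, only the one from compound 1 to compound 3 matches this kind of change, a swap of the ring on the amide-type nitrogen with the amide hydrogen retained, and that step was within the scatter. The steps of a 14-fold lower number from compound 1 to compound 2 (1.16 log units; beyond the scatter) and an 8.4-fold higher number from compound 2 to compound 3 (0.93 log units; beyond the scatter) both involve morpholin-4-yl on the carbonyl carbon, which removes the amide hydrogen, so they do not bear on compound 4 directly.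

The expectation for compound 4 is therefore a step of no real size, a 1.3-fold lower number from compound 1 to compound 4 (0.10 log units; within the scatter), within the scatter. Compound 4 is estimated at 1800 nM, with a range from 700 nM to 4500 nM.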

Compound 4, half-maximal inhibitory concentration: 100 nM
Estimate against measurement, compound 4: 18-fold (1.26 log units) above, outside the stated range (below it).
By their numbers in this assay, from the lowest: compounds 4 and 2 (each within the scatter of the next); then compounds 3 and 1 (each within the scatter of the next).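

In this assay, the ring on the amide-type nitrogen turns out to matter even with the amide hydrogen kept: oxolan-3-yl gives a 23-fold lower number from compound 1 to compound 4 (1.36 log units; beyond the scatter) and a 14-fold lower number from compound 3 to compound 4 (1.13 log units; beyond the scatter) on the same nitrogen, although the swap from 4-methoxycyclohexyl to oxan-4-yl had stayed within the scatter. A low number at this position therefore does not depend on losing the amide hydrogen, since the secondary amide of compound 4 and the morpholin-4-yl amide of compound 2 are level, with a 1.6-fold lower number from compound 2 to compound 4 (0.20 log units; within the scatter) on the same core. Nothing in hand accounts for why the five-membered oxolan-3-yl ring separates so sharply from the six-membered rings on this nitrogen.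

Still open, going by these compounds, is whether the ring oxygen of oxolan-3-yl is needed at all, a question that cyclopentyl on the same nitrogen would address, and whether a smaller oxetan-3-yl ring or a pyrrolidin-3-yl ring, with an amine in place of that oxygen, would hold the same level. The compounds shown also carry only one configuration at the oxolan-3-yl stereocentre, so the weight of that centre remains unknown.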